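Arylsulfonamides with a shared core: N-aryl changes and growth inhibition

The source may hold more compounds than are shown below. What is called first, only, known or untested is meant among the compounds shown, and "the series" means these compounds.

Measured compounds and values:
- compound 1 `CC(C)Cc1ccc(NS(=O)(=O)c2ccc(N3CCNC3=O)cc2)cc1`: > 1000 nM
- compound 2 `COc1ccccc1NS(=O)(=O)c1ccc(N2CCNC2=O)cc1`: 300 nM
- compound 3 `CC(C)(C)c1ccc(NS(=O)(=O)c2ccc(N3CCNC3=O)cc2)cc1`: > 1000 nM

In a functional assay on M21 cells (Homo sapiens) for antiproliferative activity, read by sulforhodamine B assay, with a stated time of 48 h (on this read-out lower numbers stand for stronger inhibition and higher numbers for weaker inhibition), compound 1 reaches only a limit of the assay, > 1000 nM. Compound 3 likewise gives only a limit in this assay, > 1000 nM. Compound 2 is the one member of the set with a numerical result, 300 nM in this assay, so it stands alone on the numbers shown. No ordering of compound 1 or compound 3 against compound 2 can be read. Among the measured compounds shown here, the single measured step, a step that the two limits leave unreadable from compound 1 to compound 3, is itself unreadable, because both of its ends sit at the limit of > 1000 nM in this assay, at which 2 of the 3 values shown sit.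

The unmeasured compound 4 `Cc1ccc(C)c(NS(=O)(=O)c2ccc(N3CCNC3=O)cc2)c1` differs from compound 2 in one place: 2,5-dimethylphenyl in place of 2-methoxyphenyl on a sulfonamide nitrogen. For the measured compounds named here, no measured step concerns this position, since the step from compound 1 to compound 3 alters an aromatic carbon substituent and not the group on the sulfonamide nitrogen, and its size cannot be read in any case. The expectation therefore rests on compound 2 alone, with a wide margin, and an estimated step of a 2.0-fold higher number from compound 2 to compound 4 (0.30 log units; within the scatter) that is not expected to exceed the scatter in either direction with any confidence. Compound 4 is expected to give about 600 nM in this assay, within 200 nM to 3000 nM.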

Compound 4, half-maximal inhibitory concentration: 27 nM
Beside the measured number, compound 4's estimate is 22-fold (1.35 log units) above it; measured number below the stated range.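

In this assay, among the compounds shown here, 2,5-dimethylphenyl in place of 2-methoxyphenyl on a sulfonamide nitrogen gives an 11-fold lower number from compound 2 to compound 4 (1.05 log units; beyond the scatter), the first readable evidence that the group at this position can move the result well beyond the scatter. The two groups have the same number of heavy atoms, and each has one six-membered aromatic ring of carbon only, so the step comes with an exchange of aryl substitution and not with a change in heavy-atom count; the leaving group holds an oxygen and a hydrogen-bond acceptor, and the entering group holds neither. The other step in the series, between compound 1 and compound 3, cannot be read, and it offered no such information on the group at this position: the limit of > 1000 nM in this assay, at which 2 of the 4 values shown sit.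

Still open is whether the step follows the loss of the methoxy group, the presence of the two methyl groups, or both together, since compound 4 changes these in a single exchange and the compounds shown do not separate them. Also open, going by these compounds, is how an aryl group carrying an amine or a carboxylic acid on the sulfonamide nitrogen would read in this assay.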